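This account rests on a few compounds, and the source may have more. Where it says the series, first, only, none or still open, it means among the compounds named here.

Among the compounds with values here, compound 2 `COc1cc(-c2cc(C(=O)/C=C/c3ccccc3)nc3cc(-c4ccccc4)nn23)cc(OC)c1OC` is one of two compounds measured in a functional assay on MDA-MB-231 cells (Homo sapiens) for antiproliferative activity, read by MTT assay, with a stated time of 24 h; a higher number here means a weaker inhibitor, a lower number a stronger inhibitor. Compound 2 gives 19200 nM, the lowest of the two numbers, and its closest neighbour is compound 1 `COc1cc(-c2cc(C(=O)/C=C/c3ccc(Cl)cc3)nc3cc(-c4ccccc4)nn23)cc(OC)c1OC`, which in this assay gives 21600 nM. Within the data shown here, the only step between measured compounds, hydrogen in place of chloro on an aromatic carbon, is a 1.1-fold lower number from compound 1 to compound 2 (0.05 log units; within the scatter), so the two compounds cannot be ordered.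

Compound 3 `COc1ccc(/C=C/C(=O)c2cc(-c3cc(OC)c(OC)c(OC)c3)n3nc(-c4ccccc4)cc3n2)cc1OC` has not yet been measured. It differs from compound 2 by 3,4-dimethoxyphenyl in place of phenyl on a double-bonded chain carbon bound to a double-bonded chain carbon. Among the measured compounds shown here, no measured step changes this ring in the same way; the one measured step, which also alters this ring, was within the scatter. On that basis no step beyond the scatter is expected in this assay for compound 3, and the estimate is 15000 nM, with a range from 5000 nM to 45000 nM. The expected step is a 1.3-fold lower number from compound 2 to compound 3 (0.11 log units; within the scatter).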

Compound 3, half-maximal inhibitory concentration: 14200 nM
Beside the measured number, compound 3's estimate is 1.1-fold (0.02 log units) above it; the range from low to high includes it.
By their numbers in this assay, from the lowest: compounds 3, 2 and 1 (each within the scatter of the next).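

Compound 3 carries a bigger change at this place than the earlier pair did: 3,4-dimethoxyphenyl, with 10 heavy atoms and 2 hydrogen-bond acceptors, in place of phenyl, which has 6 heavy atoms and none. Even so, in this assay the step is a 1.4-fold lower number from compound 2 to compound 3 (0.13 log units; within the scatter), and against the 4-chlorophenyl group it is a 1.5-fold lower number from compound 1 to compound 3 (0.18 log units; within the scatter), so the three groups on this double-bonded chain carbon cannot be ordered. Nothing given here offers a reason for this result.

From the compounds shown here alone, whether a ring bearing an amine or a carboxylic acid, or an open alkyl chain in place of the ring, would give a step beyond the scatter at this place remains open. Going by these compounds, the shared core is the same in all three compounds, so how changes elsewhere would read also remains unknown.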